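A few compounds are considered here, and "the series" means these few. Any claim that something is new, unique, unknown or untested is made for them only; others in the source may bear on it.

Measured so far in a functional assay on MGC-803 cells (Homo sapiens) for cytotoxicity, read by MTT assay, with a stated time of 72 h; on this read-out lower numbers stand for stronger inhibition and higher numbers for weaker inhibition:

- compound 1, `CCCCCCCCNc1nc(SCc2ccc(C(F)(F)F)cc2)nc2ccccc12`: 12600 nM
- compound 2, `CCCCCCCCCCCCCCNc1nc(SCc2ccc(C(F)(F)F)cc2)nc2ccccc12`: limit of the assay, > 50000 nM
- compound 3, `O=[N+]([O-])c1cccc(Nc2nc(SCc3ccc(C(F)(F)F)cc3)nc3ccccc23)c1`: limit of the assay, > 50000 nM

Compound 3 sits at the limit of > 50000 nM in this assay, at which 2 of the 3 values shown sit, so only a limit is known for it, with no number. The two measured steps both run into that limit: an at least 3.9-fold higher number from compound 1 to compound 2 (0.59 log units; beyond the scatter), and an at least 3.9-fold higher number from compound 1 to compound 3 (0.59 log units; beyond the scatter).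

Compound 4, `COc1ccc(Nc2nc(SCc3ccc(C(F)(F)F)cc3)nc3ccccc23)cc1OC`, differs from compound 3 as follows: 3,4-dimethoxyphenyl in place of 3-nitrophenyl on a nitrogen on an aromatic ring. Within the data shown here, no measured step swaps one aryl group for another on this nitrogen, so the only guidance is that the aryl compound 3 sits at the limit. The value is expected to stay near it, with a possible small improvement. Compound 4 is therefore estimated at 40000 nM, range 12000 nM to 150000 nM. The expected step is an at least 1.2-fold lower number from compound 3 to compound 4 (0.09 log units; that floor lies within the scatter).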

Compound 4, half-maximal inhibitory concentration: 16300 nM
Estimate against measurement, compound 4: 2.5-fold (0.39 log units) above; low and high end bracket the measured number.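

On the nitrogen on an aromatic ring, an aryl group does not by itself put a compound at the limit in this assay: 3,4-dimethoxyphenyl in place of 3-nitrophenyl gives an at least 3.0-fold lower number from compound 3 to compound 4 (0.48 log units; beyond the scatter). That step starts from a limit and not a number, so it has only a floor: the limit of > 50000 nM in this assay, at which 2 of the 4 values shown sit. Exchanging octyl for 3,4-dimethoxyphenyl gives a 1.3-fold higher number from compound 1 to compound 4 (0.11 log units; within the scatter), so these two groups are not told apart here. Still open, on these data alone, is how a butyl chain or an unsubstituted phenyl on this nitrogen would read. Also open, as far as these compounds go, is whether a single methoxy group would be enough to stay off the limit.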